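The source may report more compounds than this note shows. Statements on the series, on what has been measured and on what is new or still open speak of the compounds shown alone.

Compound 1 `CCOC(=O)C1=Cc2ccccc2OC1(OCc1cn(CC(=O)Nc2ccccc2Br)nn1)C(F)(F)F` gives > 150000 nM in a functional assay on DU-145 cells (Homo sapiens) for inhibition, read by MTT assay, with a stated time of 24 h (on this read-out higher numbers stand for weaker inhibition and lower numbers for stronger inhibition), which is a limit of the assay rather than a number.
Compound 2 `CCOC(=O)C1=Cc2ccccc2OC1(OCc1cc(-c2ccc(Br)cc2)no1)C(F)(F)F` gives 71700 nM in this assay.
Compound 3 `CCOC(=O)C1=Cc2ccccc2OC1(OCc1cc(-c2ccc(Cl)cc2)no1)C(F)(F)F` gives 18200 nM in this assay.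

Compound 1 stands at the limit of > 150000 nM in this assay, at which 1 of the 3 values shown sits, so its place among the measured values is known only as a limit. Compound 4 `CCOC(=O)C1=Cc2ccccc2OC1(OCc1cn(-c2cccc(OC)c2)nn1)C(F)(F)F` differs from compound 1 by 3-methoxyphenyl in place of ((2-bromophenyl)carbamoyl)methyl on an aromatic nitrogen. Going by the values given here, the only measured step, a 3.9-fold lower number from compound 2 to compound 3 (0.60 log units; beyond the scatter), concerns a change on an aromatic carbon in compounds 2 and 3 and does not touch an aromatic nitrogen, so it gives no guide to the direction or size of the change from compound 1 to compound 4. Compound 4 is therefore expected to give about 120000 nM, between 40000 nM and 300000 nM. The step of an at least 1.2-fold lower number from compound 1 to compound 4 (0.09 log units; that floor lies within the scatter) is expected to stay within the scatter, with a real chance that only a limit is reported again.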

Compound 4, half-maximal inhibitory concentration: > 150000 nM
Compound 4 ended at the assay's limit (the forecaster's own chance of this, stated with the estimate: 45%); at least 1.2-fold (0.09 log units) between middle value and limit.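

No step from compound 1 to compound 4 can be read, because both compounds end at a limit of the assay rather than a number: the limit of > 150000 nM in this assay, at which 2 of the 4 values shown sit.

The compounds shown leave open whether 3-methoxyphenyl in place of ((2-bromophenyl)carbamoyl)methyl changes inhibition at all.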